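Adding one methyl to compound 2

This account rests on a few compounds, and the source may have more. Where it says the series, first, only, none or still open, it means among the compounds named here.

In an ADME assay on MT4 cells (Homo sapiens) for cytotoxicity, read by MTT assay (a higher number here means that more compound is tolerated, a lower number that less compound is tolerated), compound 1 (`O=C(CSc1nc(Cc2c(Cl)cccc2Cl)cc(=O)[nH]1)c1ccc(F)cc1`) gives > 59000 nM as a limit only. Compound 2 (`COc1ccc(C(=O)CSc2nc(Cc3c(Cl)cccc3Cl)cc(=O)[nH]2)cc1`) gives > 11000 nM as a limit too, so it has no exact number. Among the compounds with values here, compound 3 (`COc1ccc(C(=O)CSc2nc(Cc3c(Cl)cccc3Cl)c(C)c(=O)[nH]2)cc1`) differs from compound 2 by methyl in place of hydrogen on an aromatic carbon as its single change, methyl in place of hydrogen. Within the data shown here, the only measured step is a step that the two limits leave unreadable from compound 1 to compound 2 and has no readable size, so it points in no direction. In this assay the estimated step is a step that the limit leaves unreadable from compound 2 to compound 3 and none beyond the scatter is expected. Compound 3 is expected near 20000 nM with an estimated range of 7000 nM to 70000 nM and may again give only a limit.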

Compound 3, half-maximal cytotoxic concentration: > 56000 nM
Compound 3: no number, only a limit; the forecaster's own chance of this, stated with the estimate: 65%; at least 2.8-fold (0.44 log units) between middle value and limit.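

Compound 2 and compound 3 each give only a limit in this assay, and the step between them cannot be read. The exact concentration at which any of these compounds becomes toxic to the cells remains open.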